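Compound 3 to compound 4: a side chain exchanged

The compounds below may be only part of what the source reports. "The series", "measured", "known", "first", "only" and "open" are said of these compounds alone.

Measured compounds in an ADME assay on HepG2 2.2.15 cells (Homo sapiens) for cytotoxicity, read by MTT assay, with a stated time of 8 days (on this read-out higher numbers stand for lower toxicity in this test and lower numbers for higher toxicity in this test), and their values:
- Compound 1 `O=c1c(CO)cc(-c2ccc(F)nc2F)nn1Cc1ccc(Cl)cc1` gives > 100000 nM as a limit of the assay
- Compound 2 `CN(C)c1ccc(-c2nn(Cc3ccc(C#N)cc3)c(=O)c3ccccc23)c(F)n1` gives 79200 nM
- Compound 3 `CN(C)CCNc1nc(F)c(-c2nn(Cc3ccc(C#N)cc3)c(=O)c3ccccc23)cc1Cl` gives 9760 nM

Compound 3 (9760 nM) holds the lowest number of the three in this assay and stands clearly under compound 2 (79200 nM), by more than the usual scatter. The entry for compound 1 (> 100000 nM) is a limit of the assay.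

Compound 4 `N#Cc1ccc(Cn2nc(-c3cc(Cl)c(NCC(O)CO)nc3F)c3ccccc3c2=O)cc1` has not yet been measured. It carries 1,2-dihydroxyethyl in place of (dimethylamino)methyl on a saturated chain carbon bound to a nitrogen on an aromatic ring. Among the compounds with values here, no measured pair shows this change alone, so only an expectation can be given. Of the measured compounds, only compound 3 (9760 nM) carries 2-(dimethylamino)ethyl, while compound 2 lacks it and reads higher (79200 nM), although the two differ elsewhere too. The expected result in this assay is a 4.1-fold higher number from compound 3 to compound 4 (0.61 log units; beyond the scatter) towards a higher number, beyond the scatter. Compound 4 is estimated at 40000 nM (expected range 15000 nM to 100000 nM).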

Compound 4, half-maximal cytotoxic concentration: > 100000 nM
Compound 4: only a limit was reported (the forecaster's own chance of this, stated with the estimate: 30%); middle value at least 2.5-fold (0.39 log units) from the limit.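

Within the data shown here, the exchange of (dimethylamino)methyl for 1,2-dihydroxyethyl on a saturated chain carbon bound to a nitrogen on an aromatic ring gives an at least 10-fold higher number from compound 3 to compound 4 (1.01 log units; beyond the scatter) in this assay, the first step here that changes one place alone. It ties the low number of compound 3 to this side chain, since the rest of the structure is shared with compound 4. In this assay compound 4 gives > 100000 nM, a limit of the assay, and the true size of the step stays unknown because this value is not an exact number: the limit of > 100000 nM in this assay, at which 2 of the 4 values shown sit.

As far as these compounds go, it remains open whether the lower number of compound 3 follows the dimethylamino nitrogen itself or the absence of the two hydroxyl groups. Also open, from the compounds shown here alone, is how a primary amine, a morpholine or a carboxylic acid at this position would read.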